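Benzyl for acetyl on the hydroxylated core

A few compounds are considered here, and "the series" means these few. Any claim that something is new, unique, unknown or untested is made for them only; others in the source may bear on it.

Measured in a functional assay on KB 3-1 cells (Homo sapiens), with a stated time of 1 h (a higher number here means that more compound is needed for the effect, a lower number that less compound is needed), as follows
compound 1 `CC(=O)Oc1c(O)cc2oc(-c3ccccc3)cc(=O)c2c1O` gives 11000 nM
compound 2 `COc1cc2oc(-c3ccccc3)cc(=O)c2c(OC)c1OC(C)=O` gives 11500 nM
compound 3 `CC(=O)Oc1cc2oc(-c3ccccc3)cc(=O)c2c(OCc2ccccc2)c1OC(C)=O` gives 3700 nM

Compound 1 cannot be told apart from compound 2, and its number stands beyond the scatter above that of compound 3. Compound 4 `O=c1cc(-c2ccccc2)oc2cc(O)c(OCc3ccccc3)c(O)c12` has benzyl in place of acetyl on an oxygen on an aromatic ring and otherwise matches compound 1. Among the measured compounds shown here, no measured pair isolates this change. For the measured compounds named here, compound 3 (3700 nM) is the only measured compound carrying benzyl, but it differs from compound 1 in more than one place, so it offers weak guidance. The estimated 1.8-fold lower number from compound 1 to compound 4 (0.26 log units; within the scatter) is expected to be a modest fall that stays within the scatter. Compound 4 is estimated at 6000 nM (range 2500 nM to 14000 nM).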

Compound 4, half-maximal effective concentration: 1800 nM
Estimate against measurement, compound 4: 3.3-fold (0.52 log units) above, outside the stated range (below it).
By their numbers in this assay, from the lowest: compound 4; then compound 3; then compounds 1 and 2 (each within the scatter of the next).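

Acetoxy to benzyloxy on the shared core gives the first single-place comparison in this assay: a 6.1-fold lower number from compound 1 to compound 4 (0.79 log units; beyond the scatter) shows that the number at this oxygen on an aromatic ring responds to the group it carries. Benzyl, with its aromatic ring, is accepted here in place of acetyl and brings a fall beyond the scatter. No measurement available here explains the fall.

As far as these compounds go, whether the fall depends on the aromatic ring of benzyl or on the loss of acetyl remains open. A longer chain or an amine at this oxygen could separate the two.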